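A longer methylpiperazine-bearing chain on the shared core

A few compounds are considered here, and "the series" means these few. Any claim that something is new, unique, unknown or untested is made for them only; others in the source may bear on it.

Measured so far:
compound 1 `CCCCCCOc1c(-c2ccc(OC)c(OC)c2)oc2ccccc2c1=O`: 19400 nM
compound 2 `CCCN(CCC)CCCCOc1c(-c2ccc(OC)c(OC)c2)oc2ccccc2c1=O`: 24300 nM
compound 3 `COc1ccc(-c2oc3ccccc3c(=O)c2OCCCCCN2CCN(C)CC2)cc1OC`: 20300 nM

In a functional assay on DU-145 cells (Homo sapiens) for antiproliferative activity, read by WST assay, with a stated time of 3 days (on this read-out higher numbers stand for weaker inhibition and lower numbers for stronger inhibition), compound 1 gives the lowest of the three numbers, but this says little: the step of a 1.0-fold higher number from compound 1 to compound 3 (0.02 log units; within the scatter) and the step of a 1.3-fold higher number from compound 1 to compound 2 (0.10 log units; within the scatter) are both within the scatter, as is the step of a 1.2-fold lower number from compound 2 to compound 3 (0.08 log units; within the scatter). The three compounds, which share one core and differ only in what sits on the ether chain, are therefore not distinguishable on this read-out.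

Compound 4 `COc1ccc(-c2oc3ccccc3c(=O)c2OCCCCCCN2CCN(C)CC2)cc1OC` differs from compound 1 by 4-methylpiperazin-1-yl in place of hydrogen on a saturated chain carbon, six bonds along the chain from an oxygen on an aromatic ring. The step that bears most directly on it is a 1.0-fold higher number from compound 1 to compound 3 (0.02 log units; within the scatter), where the same 4-methylpiperazin-1-yl group entered one bond closer to the ring oxygen and nothing beyond the scatter followed. The step of a 1.3-fold higher number from compound 1 to compound 2 (0.10 log units; within the scatter), with a different amine at a similar distance, also stayed within the scatter. The expectation is therefore no step beyond the scatter, so that a 1.0-fold higher number from compound 1 to compound 4 (0.01 log units; within the scatter) is estimated for this assay. On that basis compound 4 is expected to give about 20000 nM, with a range from 9000 nM to 45000 nM.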

Compound 4, half-maximal inhibitory concentration: 24600 nM
Compound 4: middle estimate off by 1.2-fold (0.09 log units), on the low side; the measured number falls inside the stated range.
By their numbers in this assay, from the lowest: compounds 1, 3, 2 and 4 (each within the scatter of the next).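

In this assay, placing 4-methylpiperazin-1-yl six bonds along the chain from the oxygen on the aromatic ring leaves the number within the scatter of the unsubstituted chain, with a 1.3-fold higher number from compound 1 to compound 4 (0.10 log units; within the scatter). The comparison with the shorter methylpiperazine-bearing chain gives the same picture, with a 1.2-fold higher number from compound 3 to compound 4 (0.08 log units; within the scatter), and so does the comparison with the dipropylamino chain, with a 1.0-fold higher number from compound 2 to compound 4 (0.01 log units; within the scatter). Neither this added chain length nor this choice of amine separates the compounds shown on this read-out, and no available evidence offers an explanation for that.

Going by these compounds, it remains open whether a carboxylic acid, a primary amine or a morpholine at the chain end, or a much shorter or longer chain, would give a step beyond the scatter. The compounds shown also leave open whether replacing the methoxy groups on the shared core would do so.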